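The compounds below may be only part of what the source reports. "The series", "measured", "known", "first", "only" and "open" are said of these compounds alone.

Three compounds share one core: compound 1 `Cc1ccc2c(NCc3ccc(NC(=O)C4CCN(Cc5ccccc5)CC4)cc3)nc(N3CCN[C@@H](C)C3)nc2c1`, compound 2 `Cc1ccc2c(NCc3ccc(NC(=O)C4CCN(Cc5ccccc5)CC4)cc3)nc(N3CCNC(CCO)C3)nc2c1` and compound 3 `Cc1ccc2c(NCc3ccc(NC(=O)C4CCN(CC5CCNCC5)CC4)cc3)nc(N(C)C)nc2c1`. All three were tested in a functional assay on SV5A8 cells (Homo sapiens) for cytotoxicity; on this read-out lower numbers stand for stronger inhibition and higher numbers for weaker inhibition. Compound 1 returns only a limit of the assay, > 8860 nM. Compound 2 likewise returns only a limit, > 8420 nM. Compound 3 too returns only a limit, > 8070 nM. For the measured compounds named here, the one single-point step among them, a step that the two limits leave unreadable from compound 1 to compound 2, stays unreadable because both of its ends are limits the limit of > 8860 nM in this assay, at which 1 of the 3 values shown sits (the limit of > 8420 nM in this assay, at which 1 of the 3 values shown sits). Compound 3 thus stands where every other measured compound stands, at a limit (the limit of > 8070 nM in this assay, at which 1 of the 3 values shown sits), and no order among the three can be stated. Compound 4 `Cc1ccc2c(NCc3ccc(NC(=O)C4CCN(Cc5ccc(F)cc5Cl)CC4)cc3)nc(N(C)C)nc2c1` differs from compound 3 in one place: 2-chloro-4-fluorophenyl in place of piperidin-4-yl on a saturated chain carbon bound to an amine nitrogen in a ring. Going by the values given here, no measured step bears on this change, since the only step available cannot be read. The estimate for compound 4 is that it is expected to sit again near the limit, about 9000 nM, with a range from 3000 nM to 30000 nM, so that the expected step that the limit leaves unreadable from compound 3 to compound 4 is not expected to exceed the scatter.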

Compound 4, half-maximal inhibitory concentration: > 5910 nM
Compound 4 gave a limit, no number (the forecaster's own chance of this, stated with the estimate: 75%); the middle value lies beyond the limit too.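

Compound 3 and compound 4 both return only limits in this assay, so the step between them cannot be read. The compounds shown leave open whether 2-chloro-4-fluorophenyl in place of piperidin-4-yl changes this read-out at all, and how the four compounds rank.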